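The source may report more compounds than this note shows. Statements on the series, on what has been measured and on what is new or still open speak of the compounds shown alone.

Of the compounds shown here, three built on a shared core have been measured in an assay on CHO-K1 cells for antagonist activity at adenosine receptor A1 (Homo sapiens), read by a beta-galactosidase reporter, with stated times of 15 min and 6 h; on this read-out lower numbers stand for stronger inhibition and higher numbers for weaker inhibition. Compound 1 `CCN(CC)Cc1cc2c(N)nc(-c3ccco3)nc2s1` gives 2130 nM, compound 2 `Nc1nc(-c2ccco2)nc2sc(CNC3CC3)cc12` gives 1890 nM, and compound 3 `Nc1nc(-c2ccco2)nc2sc(CN3CCC(F)CC3)cc12` gives 740 nM. Compound 3 thus stands lowest of the three numbers: the step of a 2.9-fold lower number from compound 1 to compound 3 (0.46 log units; beyond the scatter) and the step of a 2.6-fold lower number from compound 2 to compound 3 (0.41 log units; beyond the scatter) both lie beyond the scatter, whereas the step of a 1.1-fold lower number from compound 1 to compound 2 (0.05 log units; within the scatter) does not.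

Compound 4 `Nc1nc(-c2ccco2)nc2sc(CN3CCC(O)CC3)cc12` has not yet been measured. It differs from compound 3 in one place: hydroxy in place of fluoro on a saturated ring carbon. Going by the values given here, none of the measured steps touches this position; each of them exchanges the whole group on the saturated chain carbon bound to an aromatic carbon, and those exchanges ranged in size from within the scatter to modest. Among the compounds with values here, the change from compound 3 to compound 4 only turns 4-fluoropiperidin-1-yl into 4-hydroxypiperidin-1-yl, so there is no direct precedent for it among the measured pairs. On that basis the step of a 1.3-fold higher number from compound 3 to compound 4 (0.11 log units; within the scatter) is expected to be small, with no direction that can be asserted beyond the scatter. Compound 4 is estimated to give 950 nM in this assay, within a range from 350 nM to 2600 nM.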

Compound 4, inhibition constant: 4000 nM
Beside the measured number, compound 4's estimate is 4.2-fold (0.62 log units) below it, and the stated range ends below it.
By their numbers in this assay, from the lowest: compound 3; then compounds 2, 1 and 4 (each within the scatter of the next, the first and the last beyond it).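

Going by these compounds alone, changing one heavy atom at this saturated ring carbon, three ring bonds from the ring nitrogen, is enough to move the number in this assay: a 5.4-fold higher number from compound 3 to compound 4 (0.73 log units; beyond the scatter) shows that this position, untouched by the earlier steps, is not indifferent to what it carries. The low number of compound 3 also does not carry over to the 4-hydroxypiperidin-1-yl group, for a 1.9-fold higher number from compound 1 to compound 4 (0.27 log units; within the scatter) stays level with the diethylamino compound, while a 2.1-fold higher number from compound 2 to compound 4 (0.33 log units; beyond the scatter) puts it on the weaker side of the cyclopropylamino compound. Nothing measured here accounts for the effect of the exchange.

The compounds shown leave open whether fluoro lowers the number or hydroxy raises it, a question that a plain piperidin-1-yl group, with only hydrogen on that ring carbon, would help to settle. Going by these compounds, it also remains open where a methoxy or an amino group on the same carbon would fall relative to fluoro and hydroxy.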